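The source may hold more compounds than are shown below. What is called first, only, known or untested is meant among the compounds shown, and "the series" means these compounds.

Compound 1 `CCOC(=O)c1cc(-c2cc(OC)c(OC)c(OC)c2)c(-c2ccc(OC)c([N+](=O)[O-])c2)s1`, in a functional assay on HT-1080 cells (Homo sapiens) for antiproliferative activity, read by MTT assay, with a stated time of 72 h (a higher number here means a weaker inhibitor, a lower number a stronger inhibitor), gives 12700 nM. Compound 2 `CCOC(=O)c1cc(-c2cc(OC)c(OC)c(OC)c2)c(-c2ccc(OC)c(OCc3ccccc3)c2)s1` reaches only a limit of the assay, > 100000 nM. Compound 3 `CCOC(=O)c1cc(-c2ccc(OC)c([N+](=O)[O-])c2)c(-c2cc(OC)c(OC)c(OC)c2)s1` gives 26100 nM.

Compound 1 and compound 3 are built from the same atoms joined differently; the difference between the two cores is not broken down here. Of the two, compound 3 gives the higher number. The change from compound 1 to compound 2 is benzyloxy in place of nitro on an aromatic carbon, and the step it made was an at least 7.8-fold higher number from compound 1 to compound 2 (0.89 log units; beyond the scatter), which rests on (the limit of > 100000 nM in this assay, at which 1 of the 3 values shown sits).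

Compound 4 `CCOC(=O)c1cc(-c2ccc(OC)c(OCc3ccccc3)c2)c(-c2cc(OC)c(OC)c(OC)c2)s1` carries the same change applied to compound 3: benzyloxy in place of nitro on an aromatic carbon. Because the step of an at least 7.8-fold higher number from compound 1 to compound 2 (0.89 log units; beyond the scatter) was at least modest, a step of similar size is expected here, a 7.7-fold higher number from compound 3 to compound 4 (0.88 log units; beyond the scatter). The value expected for compound 4 is therefore 200000 nM, most likely reported only as a limit.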

Compound 4, half-maximal inhibitory concentration: > 100000 nM
Compound 4: only a limit was reported; the forecaster's own chance of this, stated with the estimate: 75%; the middle value lies beyond the limit too.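

In this assay, putting benzyloxy in place of nitro gives a weaker compound on the second core as well, with an at least 3.8-fold higher number from compound 3 to compound 4 (0.58 log units; beyond the scatter). The direction of the change therefore carries over between these two cores, but the comparison of its size stays unsettled: the same change on two cores in this assay, an at least 7.8-fold higher number (0.89 log units; beyond the scatter) from compound 1 to compound 2 and an at least 3.8-fold higher number (0.58 log units; beyond the scatter) from compound 3 to compound 4; the limit leaves it open whether they differ Compound 2 and compound 4 are both reported only as a limit, so neither step has a known end point: the limit of > 100000 nM in this assay, at which 2 of the 4 values shown sit.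

The compounds shown leave open how a smaller group at this place, such as an amine or a hydroxy group, would behave on either core. They also leave open whether any replacement for nitro would give a lower number than compound 1 at 12700 nM.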